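Fluoro Substitution on the Phenoxy Ring of Compound 2

The compounds below may be only part of what the source reports. "The series", "measured", "known", "first", "only" and "open" are said of these compounds alone.

Measured compounds:
compound 1 `Cc1cc2c(c(Oc3cccc(NS(=O)(=O)c4ccc(Cl)cc4)c3)n1)C(=O)N(C1CC1)C2=O`: 15 nM
compound 2 `Cc1cc2c(c(Oc3cccc(NS(=O)(=O)c4ccc(Cl)cc4)c3)n1)C(=O)N(C(C)C)C2=O`: 13 nM

In a functional assay on HEK293 cells for agonist activity at Glucose-dependent insulinotropic receptor (Homo sapiens), read by cAMP accumulation, with a stated time of 30 min (on this read-out lower numbers stand for an effect already at smaller amounts and higher numbers for an effect only at larger amounts of compound), compound 1 gives 15 nM and compound 2 gives 13 nM. The two numbers sit within the scatter of each other; the step of a 1.2-fold lower number from compound 1 to compound 2 (0.06 log units; within the scatter) is too small to count as a change, so compound 2 and compound 1 are equivalent on this read-out.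

Compound 3 `Cc1cc2c(c(Oc3cc(F)cc(NS(=O)(=O)c4ccc(Cl)cc4)c3)n1)C(=O)N(C(C)C)C2=O` is not yet measured. It differs from compound 2 by fluoro in place of hydrogen on an aromatic carbon. The fluoro enters on an aromatic carbon of a six-membered aromatic ring of carbon only, meta to a ((4-chlorophenyl)sulfonyl)amino group.

Among the compounds with values here, the only measured step, from compound 1 to compound 2, concerns the substituent on the amide-type nitrogen in the ring, not the phenoxy ring, so no measured step bears on this change. There is no basis in the data for a step beyond the scatter in either direction. The step of a 1.1-fold lower number from compound 2 to compound 3 (0.03 log units; within the scatter) is therefore expected to be small. Compound 3 is estimated at 12 nM in this assay, with a range of 4 nM to 40 nM.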

Compound 3, half-maximal effective concentration: 357 nM
Compound 3: middle estimate off by 30-fold (1.47 log units), on the low side, outside the stated range (above it).
By their numbers in this assay, from the lowest: compounds 2 and 1 (each within the scatter of the next); then compound 3.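

In this assay the phenoxy ring is far more sensitive to change than the substituent on the amide-type nitrogen: fluoro in place of hydrogen on an aromatic carbon, meta to a ((4-chlorophenyl)sulfonyl)amino group, gives a 27-fold higher number from compound 2 to compound 3 (1.44 log units; beyond the scatter) while a 1.2-fold lower number from compound 1 to compound 2 (0.06 log units; within the scatter) stays inside the scatter. The entering group adds only one heavy atom, with no hydrogen-bond donor or acceptor and no net charge, so even a minimal substitution at this position can carry a large step on this read-out, which the earlier pair gave no sign of. No measurement shown bears on the origin of this step.

Going by these compounds, whether the step belongs to fluoro itself or to any replacement of hydrogen on this carbon stays open, and a chloro, methyl or methoxy group at the same place would help separate the two. Also open, on these data alone, is whether fluoro on another carbon of the phenoxy ring gives a step of similar size, and whether the same substitution behaves alike with the cyclopropyl group of compound 1 on the amide-type nitrogen.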